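This account rests on a few compounds, and the source may have more. Where it says the series, first, only, none or still open, it means among the compounds named here.

Compound 1 `Oc1cc(-c2ccc(Cl)cc2)nc2ncccc12` carries a chlorophenyl group on a two-ring core; in a functional assay on HCT-116 cells (Homo sapiens) (on this read-out lower numbers stand for stronger inhibition of growth and higher numbers for weaker inhibition of growth), compound 1 gives 32400 nM. Compound 2 `Cc1ccnc2nc(-c3ccc(Cl)cc3)cc(O)c12` differs from it by one change, (methyl in place of hydrogen on an aromatic carbon), and in this assay compound 2 gives 3720 nM. That single change produced an 8.7-fold lower number from compound 1 to compound 2 (0.94 log units; beyond the scatter), a clear gain in growth inhibition.

Compound 3 `COc1ccccc1-c1cc(O)c2cccnc2n1` keeps the same two-ring core but carries a methoxyphenyl group instead; how its core differs from that of compound 1 is not broken down here. In this assay compound 3 gives 27500 nM, which sits close to the number for compound 1 and well apart from compound 2.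

Compound 4 `COc1ccccc1-c1cc(O)c2c(C)ccnc2n1` is derived from compound 3 by the same change, (methyl in place of hydrogen on an aromatic carbon), at the same place as before. Because the earlier step was an 8.7-fold lower number from compound 1 to compound 2 (0.94 log units; beyond the scatter), a step of similar direction and roughly similar size is expected here, and this rests on that one pair alone. The expected step from compound 3 to compound 4 is a 6.1-fold lower number from compound 3 to compound 4 (0.79 log units; beyond the scatter), so compound 4 is estimated at 4500 nM, most likely between 1500 nM and 13000 nM.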

Compound 4, concentration for 50% growth inhibition: 7590 nM
Compound 4: middle estimate off by 1.7-fold (0.23 log units), on the low side, within the range that was stated.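

In this assay, methyl in place of hydrogen gives a 3.6-fold lower number from compound 3 to compound 4 (0.56 log units; beyond the scatter), so the number falls on the methoxyphenyl-bearing core as it did on the chlorophenyl-bearing core, where the same change gave an 8.7-fold lower number from compound 1 to compound 2 (0.94 log units; beyond the scatter). The two steps point the same way, and the gap in their sizes is no larger than repeated measurements could produce: the same change on two cores in this assay, an 8.7-fold lower number (0.94 log units; beyond the scatter) from compound 1 to compound 2 and a 3.6-fold lower number (0.56 log units; beyond the scatter) from compound 3 to compound 4, 2.4-fold (0.38 log units) apart, within the scatter of two such steps. Going by these compounds alone, this supports carrying the change between these two cores, but it rests on only two pairs in one cell assay, so it does not show that the gain would hold on other cores, and it does not explain why the methyl lowers the number.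

The compounds shown leave open whether something other than methyl at this same place, such as a longer chain like ethyl or an amine, would lower the number as well. They also leave open how the change behaves when the chlorophenyl or methoxyphenyl group is replaced by another group, such as a carboxylic acid-bearing ring.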